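Morpholine for thiomorpholine in a thiosemicarbazide series

A few compounds are considered here, and "the series" means these few. Any claim that something is new, unique, unknown or untested is made for them only; others in the source may bear on it.

Compound 1 `Cc1cccc(/C(N)=N/NC(=S)N2CCSCC2)n1` and compound 2 `Cc1cccc(/C(N)=N/NC(=S)N2CCOCC2)n1` share one core and differ by morpholin-4-yl in place of thiomorpholin-4-yl on a thiocarbonyl carbon. In a functional assay on A-375 cells (Homo sapiens) for cytotoxicity, read by MTT assay, with a stated time of 72 h, tested at 30 uM (a lower number here means less inhibition of growth, a higher number more inhibition of growth at the concentration tested), compound 1 gives 73.1%, and compound 2 gives 74.3%; the step is a number 1.2 percentage points higher from compound 1 to compound 2 (within the scatter). Compound 3 `N/C(=N\NC(=S)N1CCSCC1)c1ccc(F)cn1` carries a second core; how that core differs from the core of compound 1 is not broken down here. In this assay compound 3 gives 78.7%, within the scatter of the two values above. Compound 4 `N/C(=N\NC(=S)N1CCOCC1)c1ccc(F)cn1` is compound 3 with morpholin-4-yl in place of thiomorpholin-4-yl on a thiocarbonyl carbon, the same change as between compound 1 and compound 2 and at the same place. For the measured compounds named here, because the one measured instance, a number 1.2 percentage points higher from compound 1 to compound 2 (within the scatter), lies within the scatter, the expected step in this assay is about as small, a number 1.3 percentage points higher from compound 3 to compound 4 (within the scatter). Compound 4 is accordingly estimated at 80%, with a likely range from 70% to 88%.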

Compound 4, percent growth inhibition at one concentration: 85.9%
For compound 4 the middle estimate is 5.9 percentage points below the measured one; the range from low to high includes it.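

In this assay, morpholin-4-yl in place of thiomorpholin-4-yl on the core of compound 3 gives a number 7.2 percentage points higher from compound 3 to compound 4 (within the scatter). The two steps agree as far as this read-out can tell: the same change on two cores in this assay, a number 1.2 percentage points higher (within the scatter) from compound 1 to compound 2 and a number 7.2 percentage points higher (within the scatter) from compound 3 to compound 4, 6 percentage points apart, within the scatter of two such steps. No difference between the two cores can be read, but since both steps lie within the scatter, this does not show that the change moves the value on either core, and two cores give only a narrow basis for carrying it further.

On these data alone, it remains open whether other groups on the thiocarbonyl carbon, such as piperidin-1-yl or an open-chain dimethylamino group, would give values in the same range. A read-out at a single concentration also leaves open how the compounds compare across a range of concentrations.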